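Hydroxy to hydrogen in an EP3 agonist series

The source may hold more compounds than are shown below. What is called first, only, known or untested is meant among the compounds shown, and "the series" means these compounds.

Measured in a functional assay on CHO cells for agonist activity at prostaglandin E2 receptor EP3 subtype (Homo sapiens), read by fluorescence and calcium flux; on this read-out lower numbers stand for an effect already at smaller amounts and higher numbers for an effect only at larger amounts of compound:
compound 1 `O=C(O)c1csc([C@H]2CC[C@@H]3[C@@H](/C=C/[C@@H](O)COc4ccccc4)[C@H](O)C[C@@H]3O2)n1` gives 0.8 nM
compound 2 `O=C(O)c1csc([C@H]2CC[C@@H]3[C@@H](CCCOc4ccccc4)[C@H](O)C[C@@H]3O2)n1` gives 5800 nM

Going by the values given here, compound 1 holds the lowest of the two numbers; compound 2 lies far higher, beyond the scatter, but differs from compound 1 in more than one place, so no single step is known. Compound 3 `O=C(O)c1csc([C@H]2CC[C@@H]3[C@@H](/C=C/CCOc4ccccc4)[C@H](O)C[C@@H]3O2)n1` differs from compound 1 by hydrogen in place of hydroxy on a saturated chain carbon bound to a double-bonded chain carbon and a saturated chain carbon. The step of a 130-fold higher number from compound 1 to compound 3 (2.10 log units; beyond the scatter) is expected to be a clear rise, beyond the scatter, yet smaller than the gap to compound 2. Compound 3 is estimated at 100 nM, within 10 nM to 1000 nM.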

Compound 3, half-maximal effective concentration: 260 nM
For compound 3 the middle estimate is 2.6-fold (0.41 log units) below the measured one; measured number inside the range.
By their numbers in this assay, from the lowest: compound 1; then compound 3; then compound 2.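

In this assay, going by these compounds alone, hydrogen in place of hydroxy on a saturated chain carbon bound to a double-bonded chain carbon and a saturated chain carbon gives a 330-fold higher number from compound 1 to compound 3 (2.51 log units; beyond the scatter) and is the first change read on its own. With the double bond and the rest of compound 1 kept, this single hydroxy is enough for a large step. No available data offer a cause for this step.

On these data alone, whether a methoxy, an amine or a fluorine on this carbon keeps the low number of compound 1 remains open. As far as these compounds go, the effect of the double bond alone also remains open.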